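Compound 4: a new ring on the core of compound 1

The source may report more compounds than this note shows. Statements on the series, on what has been measured and on what is new or still open speak of the compounds shown alone.

Compound 1 `Cc1cc(C)c(S(=O)(=O)N2CCC(C3OCC(C)CO3)CC2)c(C)c1` — > 5000 nM
Compound 2 `CC1CCN(C2CCN(S(=O)(=O)c3ccc(Br)cc3OC(F)(F)F)CC2)CC1` — 5 nM
Compound 3 `Cc1cc(Cl)cc(Cl)c1S(=O)(=O)N1CCC(N2CCC(C)CC2)CC1` — 0.6 nM

Of the compounds shown here, three have been measured in a functional assay on DLD-1 cells (Homo sapiens) for antiproliferative activity, read by CellTiter-Glo, with a stated time of 72 h; on this read-out lower numbers stand for stronger inhibition and higher numbers for weaker inhibition. Compound 1 `Cc1cc(C)c(S(=O)(=O)N2CCC(C3OCC(C)CO3)CC2)c(C)c1` gives > 5000 nM, which is a limit of this assay and not a number. Compound 1 therefore stands at the limit of > 5000 nM in this assay, at which 1 of the 3 values shown sits, with no value of its own to place on the scale. Compound 2 `CC1CCN(C2CCN(S(=O)(=O)c3ccc(Br)cc3OC(F)(F)F)CC2)CC1` gives 5 nM in this assay, and compound 3 `Cc1cc(Cl)cc(Cl)c1S(=O)(=O)N1CCC(N2CCC(C)CC2)CC1` gives 0.6 nM. The two numbered values show that strong inhibition is reachable among these compounds, while compound 1 is the one that reaches only the limit.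

Compound 4 `Cc1cc(C)c(S(=O)(=O)N2CCC(N3CCC(C)OC3)CC2)c(C)c1` keeps the core of compound 1 and differs from it in a single place: a group of 7 heavy atoms (5 carbon, 1 nitrogen, 1 oxygen; one six-membered non-aromatic ring with 2 hetero atoms) in place of a group of 7 heavy atoms (5 carbon, 2 oxygen; one six-membered non-aromatic ring with 2 hetero atoms), on a saturated ring carbon. Among the compounds with values here, no measured pair among the three compounds covers a change of this kind, so the size of the step has to be judged from the structural change alone and from where compound 1 stands. Because compound 1 sits at the limit of > 5000 nM in this assay, at which 1 of the 3 values shown sits, any move of compound 4 to a measurable number would be a move toward stronger inhibition, and the author expects such a move, of the size given by an at least 12-fold lower number from compound 1 to compound 4 (1.09 log units; beyond the scatter). Compound 4 is thus estimated at 400 nM in this assay, with a range from 40 nM to 4000 nM.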

Compound 4, half-maximal inhibitory concentration: 92 nM
Compound 4: middle estimate off by 4.3-fold (0.64 log units), on the high side; low and high end bracket the measured number.
By their numbers in this assay, from the lowest: compound 3; then compound 2; then compound 4. At a limit, above all of these: compound 1.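

In this assay, the exchange of one ring for another on the saturated ring carbon gives an at least 54-fold lower number from compound 1 to compound 4 (1.73 log units; beyond the scatter), so this position of the core of compound 1 responds strongly to a single change. The group that leaves and the group that enters are both six-membered non-aromatic rings with 2 hetero atoms and 7 heavy atoms, with the same counts of hydrogen-bond donors and acceptors and no net charge, and they differ in that the entering ring holds 1 nitrogen and 1 oxygen where the leaving ring holds 2 oxygen, so a large shift in this assay needs no change in ring size or in those counts. The step has no upper end, as compound 1 stands at a limit and not at a number: the limit of > 5000 nM in this assay, at which 1 of the 4 values shown sits.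

The compounds shown leave open whether the same ring exchange would have a similar effect on any core other than that of compound 1. They also leave open what a morpholine ring or an open-chain dimethylamino group would do on this same ring carbon.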